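The source may report more compounds than this note shows. Statements on the series, on what has been measured and on what is new or still open speak of the compounds shown alone.

Measured compounds:
- compound 1, `COc1ccccc1COC(c1cccc(I)c1)C1CNCCO1`: 716 nM
- compound 2, `CCOc1ccccc1OC(c1cccc(I)c1)C1CNCCO1`: 3140 nM

Of the compounds shown here, two have been tested in an assay on membranes from brain for displacement of a labelled ligand from sodium-dependent dopamine transporter (Rattus norvegicus); a higher number here means a weaker inhibitor, a lower number a stronger inhibitor. Compound 1 gives 716 nM and stands as the lower of the two numbers. Compound 2, which differs from it at several places, gives 3140 nM, a higher number that lies beyond the usual scatter. For the measured compounds named here, no single-point step between the two measured compounds can be drawn, so the pair only shows that the shared core tolerates some variation at the aryl ether end with a loss that is clear but not large.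

Compound 3, `O=[N+]([O-])c1ccccc1COC(c1cccc(I)c1)C1CNCCO1`, is the next compound. Relative to compound 1 the change is nitro in place of methoxy on an aromatic carbon. With no measured step of this kind in hand, the expectation for compound 3 rests only on the pattern that compounds 1 and 2 show: a modest shift, most likely toward a higher number, with a 1.5-fold higher number from compound 1 to compound 3 (0.19 log units; within the scatter) expected. Compound 3 is therefore estimated at 1100 nM in this assay, with a range from 300 nM to 3800 nM.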

Compound 3, inhibition constant: 14.2 nM
Estimate against measurement, compound 3: 77-fold (1.89 log units) above; the measured number lies below the stated range.
By their numbers in this assay, from the lowest: compound 3; then compound 1; then compound 2.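

In this assay, the aromatic carbon ortho to a large group proves to be a place where a single exchange counts heavily: nitro in place of methoxy gives a 50-fold lower number from compound 1 to compound 3 (1.70 log units; beyond the scatter) and so brings compound 3 to 14.2 nM in this series. Compounds 1 and 2 differ at several places and could tie no change to one position, whereas this pair isolates one position and shows that the substituent there can move the number by far more than the scatter. Nothing measured here bears on why this exchange has so large an effect, so the step stands as an observation only.

As far as these compounds go, it remains open whether the lower number belongs to nitro itself or would also follow from another group at this place, such as a nitrile, a trifluoromethyl or a chlorine atom, and whether an amine or a hydroxyl there would send the number the other way. From the compounds shown here alone, it is also open whether the step would keep its size with bromine or hydrogen in place of the iodine on the other aromatic ring.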